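Swapping Azido for Hydroxy on the Amide Side Chain

A few compounds are considered here, and "the series" means these few. Any claim that something is new, unique, unknown or untested is made for them only; others in the source may bear on it.

Three compounds share one core and differ only in the group attached to the carbonyl carbon of the amide. Compound 1 `COc1ccc(CN(C(=O)C2CC2)c2cc(OC)c(OC)c(OC)c2)cc1O` carries a cyclopropyl there, and in a functional assay on KYSE-450 cells (Homo sapiens) for inhibition, read by MTT assay, with a stated time of 48 h (on this read-out higher numbers stand for weaker inhibition and lower numbers for stronger inhibition), compound 1 gives 80 nM. Compound 2 `COc1ccc(CN(C(=O)C=C(C)C)c2cc(OC)c(OC)c(OC)c2)cc1O` carries a 2-methylprop-1-en-1-yl group, and compound 2 gives 280 nM. Compound 3 `COc1ccc(CN(C(=O)CN=[N+]=[N-])c2cc(OC)c(OC)c(OC)c2)cc1O` carries an azidomethyl group, and compound 3 gives 160 nM. On these numbers compound 3 sits between the other two: a 2.0-fold higher number from compound 1 to compound 3 (0.30 log units; within the scatter) and a 1.8-fold lower number from compound 2 to compound 3 (0.24 log units; within the scatter), both within the scatter, so compound 3 cannot be called stronger or weaker than either neighbour. Only a 3.5-fold higher number from compound 1 to compound 2 (0.54 log units; beyond the scatter) reaches beyond the scatter.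

Compound 4 `COc1ccc(CN(C(=O)CO)c2cc(OC)c(OC)c(OC)c2)cc1O` has not yet been measured. It differs from compound 3 in one place: hydroxy in place of azido on a saturated chain carbon bound to a carbonyl carbon. For the measured compounds named here, no measured step exchanges azido for hydroxy, so the expectation rests on how little the series has moved so far: three different groups on the carbonyl carbon span a narrow band, and two of the three steps stay within the scatter. A step of similarly small size, with no clear direction, is therefore expected for this change as well. Compound 4 is estimated at 200 nM, with a likely range from 80 nM to 500 nM. This estimate corresponds to an expected 1.3-fold higher number from compound 3 to compound 4 (0.10 log units; within the scatter).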

Compound 4, half-maximal inhibitory concentration: 370 nM
Beside the measured number, compound 4's estimate is 1.9-fold (0.27 log units) below it; measured number inside the range.
By their numbers in this assay, from the lowest: compounds 1, 3, 2 and 4 (each within the scatter of the next, the first and the last beyond it).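

Within this assay, the azido-to-hydroxy exchange is the first change at this saturated chain carbon to move the read-out beyond the scatter, with a 2.3-fold higher number from compound 3 to compound 4 (0.36 log units; beyond the scatter) and weaker inhibition for the hydroxy compound. So this position is not indifferent to what it carries, even though compound 3 could not be told apart from either earlier neighbour. Compound 4 also widens the series, with a 4.6-fold higher number from compound 1 to compound 4 (0.67 log units; beyond the scatter) as its largest step, while a 1.3-fold higher number from compound 2 to compound 4 (0.12 log units; within the scatter) leaves hydroxymethyl and 2-methylprop-1-en-1-yl indistinguishable here; no supporting data explain these steps.

The compounds shown leave open whether the loss belongs to hydroxy in particular, and an aminomethyl or a methoxymethyl group on the same carbonyl carbon would show whether such groups read like compound 3 or like compound 4. A longer chain, such as hydroxyethyl, or a carboxylic acid at this place would show whether the number depends on the end group alone or also on how far it stands from the carbonyl.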